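Alkoxy chain extension on the shared core

The source may report more compounds than this note shows. Statements on the series, on what has been measured and on what is new or still open speak of the compounds shown alone.

Compound 2 `CCOc1cc(CCc2nc(C)c(CC)s2)nc(NCc2cc(Cl)cc(NC(=O)OC(C)C)c2)c1` gives 33 nM in an assay on cells for binding affinity to Neuropeptide Y receptor type 1 (Homo sapiens); on this read-out lower numbers stand for stronger inhibition and higher numbers for weaker inhibition; it is separated from compound 1 by a step beyond the scatter and from compound 3 by one within it. Compound 1 `CCc1sc(CCc2cc(OC)cc(NCc3cc(Cl)cc(NC(=O)OC(C)C)c3)n2)nc1C` gives 234 nM, and the steps of a 7.1-fold lower number from compound 1 to compound 2 (0.85 log units; beyond the scatter) and a 6.7-fold lower number from compound 1 to compound 3 (0.83 log units; beyond the scatter) are both beyond the scatter. Compound 3 `CCCCCOc1cc(CCc2nc(C)c(CC)s2)nc(NCc2cc(Cl)cc(NC(=O)OC(C)C)c2)c1` gives 35 nM, and the step of a 1.1-fold higher number from compound 2 to compound 3 (0.03 log units; within the scatter) lies within it.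

Compound 4 `CC/C=C\CCOc1cc(CCc2nc(C)c(CC)s2)nc(NCc2cc(Cl)cc(NC(=O)OC(C)C)c2)c1` differs from compound 2 by but-1-en-1-yl in place of hydrogen on a saturated chain carbon, two bonds along the chain from an oxygen on an aromatic ring. The step that bears on this change is a 1.1-fold higher number from compound 2 to compound 3 (0.03 log units; within the scatter), where a propyl entered at the same place and the number did not move beyond the scatter. On that basis the expected step in this assay is a 1.1-fold higher number from compound 2 to compound 4 (0.03 log units; within the scatter), with no change beyond the scatter in either direction. The estimate for compound 4 in this assay is therefore 35 nM, with a range from 15 nM to 80 nM.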

Compound 4, half-maximal inhibitory concentration: 4.7 nM
Estimate against measurement, compound 4: 7.4-fold (0.87 log units) above; the measured number lies below the stated range.
By their numbers in this assay, from the lowest: compound 4; then compounds 2 and 3 (each within the scatter of the next); then compound 1.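

The earlier flat step from ethoxy to pentyloxy did not hold for this position: the chain with the double bond gives a 7.0-fold lower number from compound 2 to compound 4 (0.85 log units; beyond the scatter) in this assay, and replacing propyl with but-1-en-1-yl at the same place gives a 7.4-fold lower number from compound 3 to compound 4 (0.87 log units; beyond the scatter). The position therefore still responds to change beyond the pentyloxy chain, and the widest step in the series is now a 50-fold lower number from compound 1 to compound 4 (1.70 log units; beyond the scatter). No supporting data on these compounds accounts for the step.

The compounds shown do not separate the contribution of the double bond from that of the longer chain, and a saturated hexyl chain at this place would bear directly on that. Also open, on these data alone, are the trans form of the double bond and whether a terminal amine on the chain is tolerated.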